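This account rests on a few compounds, and the source may have more. Where it says the series, first, only, none or still open, it means among the compounds named here.

Measured in an in vitro ADME assay on microsomes from liver (Homo sapiens) for metabolic stability; on this read-out higher numbers stand for fast clearance and lower numbers for slow clearance:
compound 1 `CC(C)NC(=O)[C@H]1CC[C@@H](n2/c(=N/C(=O)c3ccc(F)cc3)[nH]c3ccc(CN4CCCCC4)cc32)CC1` gives 302 mL.min-1.g-1
compound 2 `CC(C)NC(=O)[C@H]1CC[C@@H](n2/c(=N/C(=O)c3ccc(F)cc3)[nH]c3ccc(CN4CCC[C@H]4C(C)(C)O)cc32)CC1` gives 569 mL.min-1.g-1
compound 3 `CC(C)NC(=O)[C@H]1CC[C@@H](n2/c(=N/C(=O)c3ccc(F)cc3)[nH]c3ccc(CNCC(C)(C)O)cc32)CC1` gives 233 mL.min-1.g-1

Compound 1 stands second highest of these three numbers. Among the measured compounds shown here, the steps from it are a 1.3-fold lower number from compound 1 to compound 3 (0.11 log units; within the scatter) and a 1.9-fold higher number from compound 1 to compound 2 (0.28 log units; within the scatter), both within the scatter; the only step beyond the scatter is a 2.4-fold lower number from compound 2 to compound 3 (0.39 log units; beyond the scatter). Compound 4 `CC(C)NC(=O)[C@H]1CC[C@@H](n2/c(=N/C(=O)c3ccccc3)[nH]c3ccc(CN4CCCCC4)cc32)CC1` differs from compound 1 at another place: hydrogen in place of fluoro on an aromatic carbon. No measured step touches this position; every shown step changes the group on the saturated chain carbon bound to an aromatic carbon, so nothing can be carried over directly. No shift beyond the scatter is therefore expected in this assay. Compound 4 is estimated at 350 mL.min-1.g-1, with a range from 180 mL.min-1.g-1 to 700 mL.min-1.g-1. The expected step is then a 1.2-fold higher number from compound 1 to compound 4 (0.06 log units; within the scatter).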

Compound 4, intrinsic clearance in microsomes: 203 mL.min-1.g-1
For compound 4 the middle estimate is 1.7-fold (0.24 log units) above the measured one; low and high end bracket the measured number.
By their numbers in this assay, from the lowest: compounds 4, 3, 1 and 2 (each within the scatter of the next, the first and the last beyond it).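

In this assay, among the compounds shown here, hydrogen in place of fluoro on the aromatic carbon gives a 1.5-fold lower number from compound 1 to compound 4 (0.17 log units; within the scatter), the first reading at this place, since all earlier steps changed the group on the saturated chain carbon. With piperidin-1-yl held constant, fluoro and hydrogen at this place are not told apart on this read-out. Nothing available bears on the reason for this result.

Going by these compounds, whether chloro, methoxy or nitrile at this place would give a step beyond the scatter remains open. So does whether hydrogen in place of fluoro reads the same with the amine groups of compound 2 or compound 3.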